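Swapping the aryl group beside the ring nitrogen

The source may report more compounds than this note shows. Statements on the series, on what has been measured and on what is new or still open speak of the compounds shown alone.

Compound 1 `COc1cccc(Cc2cc(-c3ccccc3)nn(CC(=O)Nc3ccc(F)cc3)c2=O)c1` gives > 50000 nM in a functional assay on HL-60 cells (Homo sapiens), read by calcium flux (on this read-out lower numbers stand for an effect already at smaller amounts and higher numbers for an effect only at larger amounts of compound), which is a limit of the assay rather than a number. Compound 2 `COc1cccc(Cc2cc(-c3cccs3)nn(CC(=O)Nc3ccc(F)cc3)c2=O)c1` gives > 50000 nM, again only a limit. The change a step that the two limits leave unreadable from compound 1 to compound 2 is therefore unreadable, since (the limit of > 50000 nM in this assay, at which 2 of the 2 values shown sit). Compound 3 `COc1ccc(-c2cc(Cc3cccc(OC)c3)c(=O)n(CC(=O)Nc3ccc(F)cc3)n2)cc1` carries 4-methoxyphenyl in place of thiophen-2-yl on an aromatic carbon. For the measured compounds named here, no measured step bears on this change beyond the two limits, so compound 3 is expected to show a step that the limit leaves unreadable from compound 2 to compound 3 that most likely ends at the limit again. Compound 3 is estimated at 80000 nM, within 20000 nM to 400000 nM.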

Compound 3, half-maximal effective concentration: > 50000 nM
Compound 3: no number, only a limit (the forecaster's own chance of this, stated with the estimate: 80%); the middle value does not contradict the limit.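

For the compounds shown here, compound 3 also gives only a limit of the assay, so no step among compound 1, compound 2 and compound 3 can be read: the limit of > 50000 nM in this assay, at which 3 of the 3 values shown sit. The compounds shown leave open whether phenyl, thiophen-2-yl and 4-methoxyphenyl differ at all in this assay.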